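Swapping the aryl group on the ring nitrogen of compound 2

The compounds below may be only part of what the source reports. "The series", "measured", "known", "first", "only" and "open" are said of these compounds alone.

Of the compounds shown here, two of a shared core have been tested in a functional assay on HT-29 cells (Homo sapiens) for antiproliferative activity, read by MTT assay, with a stated time of 72 h; a lower number here means a stronger inhibitor, a higher number a weaker inhibitor. Compound 1 `CNC(=O)c1cc(Oc2ccc(NC(=O)c3cc4cccnc4n(-c4ccc(Cl)cc4)c3=O)cc2)ccn1` gives 390 nM, and compound 2 `CNC(=O)c1cc(Oc2ccc(NC(=O)c3cc4cccnc4n(-c4ccc(OC)cc4)c3=O)cc2)ccn1` gives 920 nM. Among these two numbers compound 2 stands highest, the weaker inhibitor; its only neighbour is compound 1, which differs from it in a single group. That single step, methoxy in place of chloro on an aromatic carbon, gave a 2.4-fold higher number from compound 1 to compound 2 (0.37 log units; beyond the scatter).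

Compound 3 `CNC(=O)c1cc(Oc2ccc(NC(=O)c3cc4cccnc4n(-c4ccc(F)c(Cl)c4)c3=O)cc2)ccn1` is not yet measured. It differs from compound 2 in one place: 3-chloro-4-fluorophenyl in place of 4-methoxyphenyl on an aromatic nitrogen. For the measured compounds named here, the one measured step bears on this change directly, since it shows what happened when chloro gave way to methoxy at the same position. Going the other way, back to a chloro-bearing ring, and adding a fluorine alongside it, the expectation is a step of similar size in the opposite direction, so that compound 3 should land near compound 1. The estimated step is a 2.6-fold lower number from compound 2 to compound 3 (0.42 log units; beyond the scatter). For compound 3 the estimate in this assay is 350 nM, with a range from 150 nM to 800 nM.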

Compound 3, half-maximal inhibitory concentration: 1810 nM
Estimate against measurement, compound 3: 5.2-fold (0.71 log units) below; measured number above the stated range.
By their numbers in this assay, from the lowest: compound 1; then compounds 2 and 3 (each within the scatter of the next).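

Compound 3 shows that a chlorine on the aryl group is not enough to hold the number near that of compound 1: in this assay, 3-chloro-4-fluorophenyl in place of 4-chlorophenyl gives a 4.6-fold higher number from compound 1 to compound 3 (0.67 log units; beyond the scatter). Against the methoxy ring, the same chlorine-bearing group gives a 2.0-fold higher number from compound 2 to compound 3 (0.29 log units; within the scatter), so this swap cannot be told apart from repeat-measurement noise, and compound 3 goes against any simple rule that chloro beats methoxy here; of the three, only compound 1, with its 4-chlorophenyl group, stands clear of the other two. Nothing among the data shown explains why these aryl groups differ as they do.

Compound 3 differs from compound 1 both in where its chlorine is named on the ring and in its added fluorine, so the compounds shown leave open which of these goes with the step, something that 3-chlorophenyl and 4-fluorophenyl groups could help to separate. Also open, from the compounds shown here alone, is how this position responds to groups of another kind, such as a ring bearing an amine or a carboxylic acid, or a plain unsubstituted phenyl ring.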